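The source may report more compounds than this note shows. Statements on the series, on what has been measured and on what is new or still open speak of the compounds shown alone.

In a physicochemical assay for solubility, read by HPLC, using the shake flask method, in phosphate buffer, measured as kinetic solubility, with a stated time of 20 h, at pH 6.5 (a higher number here means a more soluble compound, a lower number a less soluble compound), compound 3 `C[C@@H]1CN(C(=O)c2ccnc(Nc3nc4cnc(-c5ccc(F)c(C(F)(F)F)c5)cc4[nH]3)c2)C[C@H](C)N1C` gives 180000 nM and compound 1 `C[C@H]1CN(c2ccc(Nc3nc4cnc(Nc5cccc(C(F)(F)F)c5)cc4[nH]3)nc2)CCN1` gives 180000 nM, which puts the two level within the scatter of repeated measurements. For compound 2 `C[C@@H]1CN(C(=O)c2ccnc(Nc3nc4cnc(Nc5ccc(F)c(F)c5)cc4[nH]3)c2)C[C@H](C)O1`, this assay returns only a limit, < 5000 nM.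

Compound 4 `O=C(c1ccnc(Nc2nc3cnc(-c4ccc(F)c(C(F)(F)F)c4)cc3[nH]2)c1)N1CC2CC1CN2` is the next compound to be read in this series, and it departs from compound 3 in one place only, on a carbonyl carbon whose other neighbour is an aromatic carbon. There the 3,4,5-trimethylpiperazin-1-yl group leaves and a group with no common name enters: a group of 7 heavy atoms (5 carbon, 2 nitrogen; 2 five-membered non-aromatic rings with 1 hetero atom each) in place of a group of 9 heavy atoms (7 carbon, 2 nitrogen; one six-membered non-aromatic ring with 2 hetero atoms), on a carbonyl carbon. The rest of the structure stays the same.

Among the compounds with values here, none of the measured compounds differ from one another in a single place, so the data offer no direct precedent for this exchange. The expectation therefore starts from compound 3 at 180000 nM, and that single anchor is why the range is kept wide. The expected change in this assay is a 1.2-fold lower number from compound 3 to compound 4 (0.08 log units; within the scatter), and no shift beyond the scatter is expected in either direction. For compound 4 the estimated value in this assay is 150000 nM, with an expected range from 40000 nM to 300000 nM.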

Compound 4, solubility: 115000 nM
Beside the measured number, compound 4's estimate is 1.3-fold (0.12 log units) above it, within the range that was stated.
By their numbers in this assay, from the lowest: compounds 4, 1 and 3 (each within the scatter of the next). At a limit, below all of these: compound 2.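

In this assay, within the data shown here, the exchange on the carbonyl carbon gives a 1.6-fold lower number from compound 3 to compound 4 (0.19 log units; within the scatter), and this is the first step that can be read at a single place. It shows that at this position the 3,4,5-trimethylpiperazin-1-yl group, with its 2 defined stereocentres and 0 hydrogen-bond donors, can be replaced by a group of 2 five-membered non-aromatic rings carrying 1 hydrogen-bond donor, and that the reading does not leave the scatter even though the group is smaller by heavy atom count and no defined stereocentre is counted in it. No measurement shown speaks to why the step has this size.

This single exchange leaves open whether an open-chain amine such as dimethylamine, or a chain ending in a carboxylic acid, would also stay within the scatter on the same carbonyl carbon. It also leaves open how the same exchange would read on compound 2, whose reading in this assay is only a limit.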